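Fluoro on a Phenyl Ring at the Assay Limit

The source may hold more compounds than are shown below. What is called first, only, known or untested is meant among the compounds shown, and "the series" means these compounds.

Measured in a functional assay on HL-60 cells (Homo sapiens) for antiproliferative activity, with a stated time of 72 h; a lower number here means a stronger inhibitor, a higher number a weaker inhibitor:
Compound 1 `CCCC#Cc1cc([C@@H]2O[C@H](CO)[C@@H](O)[C@H]2O)n2ncnc(N)c12`: 200 nM
Compound 2 `Nc1ncnn2c([C@@H]3O[C@H](CO)[C@@H](O)[C@H]3O)cc(C#Cc3ccc(F)cc3)c12`: > 100000 nM (a limit, not a number)
Compound 3 `Nc1ncnn2c([C@@H]3O[C@H](CO)[C@@H](O)[C@H]3O)cc(-c3ccccc3)c12`: > 100000 nM (a limit, not a number)

Compound 3 has no exact number and stands at the limit of > 100000 nM in this assay, at which 2 of the 3 values shown sit. Compound 4 `Nc1ncnn2c([C@@H]3O[C@H](CO)[C@@H](O)[C@H]3O)cc(-c3ccc(F)cc3)c12` has fluoro in place of hydrogen on an aromatic carbon of compound 3: fluoro in place of hydrogen on an aromatic carbon. Two large steps start from compound 1: an at least 500-fold higher number from compound 1 to compound 2 (2.69 log units; beyond the scatter) and an at least 500-fold higher number from compound 1 to compound 3 (2.69 log units; beyond the scatter). Neither is this exchange. The comparison nearest to it gives a step that the two limits leave unreadable from compound 2 to compound 3, and compound 2 already carries a 4-fluorophenyl yet sits at the same limit. No recovery of activity is therefore expected in this assay, and the expected change is a number no higher from compound 3 to compound 4 (the limit leaves the size open), none beyond the scatter. Compound 4 is estimated at 100000 nM, with an expected range of 30000 nM to 200000 nM.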

Compound 4, half-maximal inhibitory concentration: 68300 nM
Estimate against measurement, compound 4: 1.5-fold (0.17 log units) above; the measured number falls inside the stated range.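

In this assay, among the compounds shown here, compound 4 is the first compound with a phenyl ring at this position to give a measured number, but the steps to it are only floors within the scatter: an at least 1.4-fold lower number from compound 3 to compound 4 (0.16 log units; that floor lies within the scatter) and an at least 1.4-fold lower number from compound 2 to compound 4 (0.16 log units; that floor lies within the scatter). Against the chain of compound 1, the 4-fluorophenyl still shows a large loss, with a 340-fold higher number from compound 1 to compound 4 (2.53 log units; beyond the scatter). Compound 2 and compound 3 remain limits, not numbers: the limit of > 100000 nM in this assay, at which 2 of the 4 values shown sit.

On these data alone, whether an amine or a carboxylic acid in place of fluoro would move the number stays open. So does how a longer chain in place of pent-1-yn-1-yl would compare with compound 1.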